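The source may report more compounds than this note shows. Statements on the series, on what has been measured and on what is new or still open speak of the compounds shown alone.

Measured so far in an ADME assay on HEK293 cells (Homo sapiens) for cytotoxicity, read by CellTiter-Glo and resazurin assay, with a stated time of 72 h; a lower number here means that less compound is needed, a higher number that more compound is needed for the effect:

Compound 1 `CC(C)COc1cccc(-c2ccc(C(=O)N(Cc3cccc(OCCCCCC(=O)O)c3)C(C)C)cc2)c1`: for compound 1 only a limit, > 26000 nM.
Compound 2 `COc1cc(OC)cc(-c2ccc(C(=O)N(Cc3cccc(OCCCCCC(=O)O)c3)C(C)C)cc2)c1`: for compound 2 likewise only a limit, > 26000 nM.

Compound 2 therefore stands at the limit of this assay, with no number of its own; (the limit of > 26000 nM in this assay, at which 2 of the 2 values shown sit), so the step that the two limits leave unreadable from compound 1 to compound 2 cannot be read in size or direction. Compound 3 `COc1cc(F)cc(-c2ccc(C(=O)N(Cc3cccc(OCCCCCC(=O)O)c3)C(C)C)cc2)c1` is reached from compound 2 by fluoro in place of methoxy on an aromatic carbon. No measured step bears readably on this change, since the only step shown is itself unreadable. The step of a number no higher from compound 2 to compound 3 (the limit leaves the size open) is therefore expected to be none beyond the scatter, with the outcome most likely another limit rather than a number. Compound 3 is estimated at 26000 nM, within a range of 12000 nM to 60000 nM, and the estimate rests only on compound 2 sitting at its limit > 26000 nM.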

Compound 3, half-maximal effective concentration: > 26000 nM
Compound 3 ended at the assay's limit; the forecaster's own chance of this, stated with the estimate: 80%; the middle value lies on the limit itself.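

In this assay, within the data shown here, compound 1, compound 2 and compound 3 all stand at a limit and carry no number of their own, so no step among them can be read in size or direction. The compounds shown leave open what concentration, if any, gives the effect in this assay and whether fluoro in place of methoxy alters it.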